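From 4-methylphenyl to phenyl at the assay limit

The compounds below may be only part of what the source reports. "The series", "measured", "known", "first", "only" and "open" are said of these compounds alone.

Compound 1 `COc1ccc(-c2cnc(NC(=O)c3ccc(O)cc3)n2C)cc1`: > 100000 nM
Compound 2 `COc1ccc(-c2cnc(NC(=O)c3cnco3)n2C)cc1`: > 100000 nM
Compound 3 `COc1ccc(-c2cnc(NC(=O)c3ccc(C)cc3)n2C)cc1`: > 100000 nM

In a toxicity assay on THP-1 cells (Homo sapiens) for inhibition (a higher number here means that more compound is tolerated, a lower number that less compound is tolerated), compound 3 gives > 100000 nM, which is a limit and not a number. It stands with the other two compounds at the limit of > 100000 nM in this assay, at which 3 of the 3 values shown sit.

Compound 4 `COc1ccc(-c2cnc(NC(=O)c3ccccc3)n2C)cc1` carries hydrogen in place of methyl on an aromatic carbon, para to a large group, so that 4-methylphenyl becomes phenyl: hydrogen in place of methyl on an aromatic carbon.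

The nearest measured change is a step that the two limits leave unreadable from compound 1 to compound 3, with methyl in place of hydroxy on an aromatic carbon. A second change bearing on compound 3 is a step that the two limits leave unreadable from compound 2 to compound 3, with 4-methylphenyl in place of 1,3-oxazol-5-yl on a carbonyl carbon. Neither gives a size to carry over, so no step beyond the scatter is expected in this assay, and no direction is favoured.

The expected step is a number no higher from compound 3 to compound 4 (the limit leaves the size open). Compound 4 is estimated at 100000 nM, with an expected range from 60000 nM to 170000 nM, and is expected to be reported as a limit again.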

Compound 4, half-maximal cytotoxic concentration: > 100000 nM
Compound 4: no number, only a limit; the forecaster's own chance of this, stated with the estimate: 90%; the middle value sits exactly at the limit.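

In this assay compound 4 gives > 100000 nM, which is a limit and not a number. Among these compounds, no step between compound 4 and compounds 1, 2 or 3 can be read, and all four stand together: the limit of > 100000 nM in this assay, at which 4 of the 4 values shown sit. The compounds shown leave open whether these four differ at all in this assay.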